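Bromo-substituted core: amide substituent variation in adenosine receptor binding

The compounds below may be only part of what the source reports. "The series", "measured", "known", "first", "only" and "open" are said of these compounds alone.

Compounds measured so far:
compound 1 `N=c1oc2ccc(Br)cc2cc1C(=O)NCCO`: 0%
compound 2 `N=c1oc2ccc(Br)cc2cc1C(=O)NC1CCCCC1`: 8%

The two measured compounds share one core and differ only in the group on the amide-type nitrogen. In an assay on HeLa cells for displacement of a labelled ligand from adenosine receptor A3 (Homo sapiens), read by scintillation counting, with a stated time of 180 min, tested at 10 uM (a higher number here means more inhibition at the concentration tested (going by the name of the read-out), a lower number less inhibition), compound 1 gives 0%, and compound 2 gives 8%. Among the measured compounds shown here, the single step between them, a number 8 percentage points higher from compound 1 to compound 2 (within the scatter), lies within the scatter, so on these numbers the two compounds are indistinguishable; compound 2 merely carries the higher of the two figures, with compound 1 the only other point of comparison.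

Compound 3 `CCC(CO)NC(=O)c1cc2cc(Br)ccc2oc1=N` is not yet measured. It differs from compound 2 in one place: 1-(hydroxymethyl)propyl in place of cyclohexyl on an amide-type nitrogen. For the measured compounds named here, the only step that bears on this change is a number 8 percentage points higher from compound 1 to compound 2 (within the scatter), which already exchanged a hydroxyl-bearing chain for cyclohexyl on the same nitrogen without moving the read-out beyond the scatter. Returning to a hydroxyl-bearing chain, now the branched 1-(hydroxymethyl)propyl, is therefore expected to give no step beyond the scatter, estimated as a number 5 percentage points lower from compound 2 to compound 3 (within the scatter). For compound 3 the expected value in this assay is 3%, within a range from -8% to 14%.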

Compound 3, a percentage reported as inhibition, at one concentration (the size of the read-out at that concentration, not a potency): 24%
Beside the measured number, compound 3's estimate is 21 percentage points below it, and the stated range ends below it.
By their numbers in this assay, from the lowest: compounds 1 and 2 (each within the scatter of the next); then compound 3.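

In this assay, among the compounds shown here, the group on the amide-type nitrogen now proves able to move the read-out: replacing cyclohexyl with 1-(hydroxymethyl)propyl gives a number 16 percentage points higher from compound 2 to compound 3 (beyond the scatter), the first step at this nitrogen to pass the scatter. A hydroxyl-bearing chain is not enough on its own to give this result, as compound 1 also carries one, and ethyl in place of hydrogen on the saturated chain carbon bound to the amide-type nitrogen gives a number 24 percentage points higher from compound 1 to compound 3 (beyond the scatter), so the two hydroxyl-bearing chains are separated by the added ethyl. Nothing available offers an explanation for either step.

The compounds shown leave open whether the ethyl group alone carries this step or does so only together with the hydroxyl, and how a methyl in place of that ethyl, a longer chain, or an amine in place of the hydroxyl would read in this assay. Each figure is a reading at one concentration, so the potency of these compounds also remains open.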